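Amide Variation on a Shared Core: Expecting Compound 4

A few compounds are considered here, and "the series" means these few. Any claim that something is new, unique, unknown or untested is made for them only; others in the source may bear on it.

In a functional assay on the whole organism (strain Wistar) for inhibition, with Rattus norvegicus as the target, read by paw edema, with stated times of 60 min and 4 h, at a dose of 100 mg/kg by the oral route (a lower number here means less inhibition, a higher number more inhibition at the dose given (going by the name of the read-out)), three compounds built on a shared core have been measured. Compound 1 `COc1cc2c(cc1OC)C(CC(N)=O)CC2` gives 31.3%. Compound 2 `CNC(=O)CC1CCc2cc(OC)c(OC)cc21` gives 29.7%. Compound 3 `CCN(CC)C(=O)CC1CCc2cc(OC)c(OC)cc21` gives 37.5%, the highest of the three numbers, yet its steps from both neighbours, a number 6.2 percentage points higher from compound 1 to compound 3 (within the scatter) and a number 7.8 percentage points higher from compound 2 to compound 3 (within the scatter), lie within the scatter, so the three cannot be placed in any order. The step of a number 1.6 percentage points lower from compound 1 to compound 2 (within the scatter) is likewise within the scatter.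

Compound 4 `CCCCNC(=O)CC1CCc2cc(OC)c(OC)cc21` has not yet been measured. It differs from compound 3 in one place: butylamino in place of diethylamino on a carbonyl carbon. All three measured steps vary the groups on the amide nitrogen and thus bear on this change, and none of them moved the read-out beyond the scatter. On that basis the change from compound 3 to compound 4 is expected to produce no step beyond the scatter, in no clear direction. The estimated step is a number 3.5 percentage points lower from compound 3 to compound 4 (within the scatter). Compound 4 is therefore estimated at 34%, with a range from 22% to 46%.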

Compound 4, a percentage reported as inhibition, in the whole organism at one dose (the size of the read-out at that dose, not a potency): 25%
For compound 4 the middle estimate is 9 percentage points above the measured one; the measured number falls inside the stated range.
By their numbers in this assay, from the lowest: compounds 4, 2, 1 and 3 (each within the scatter of the next, the first and the last beyond it).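

Swapping diethylamino for butylamino on a carbonyl carbon gives the only step in this series beyond the scatter (a number 12.5 percentage points lower from compound 3 to compound 4 (beyond the scatter)) in this assay, even though the two groups have the same atoms, joined differently. The result depends on the comparison, however: the other two steps, (a number 4.7 percentage points lower from compound 2 to compound 4 (within the scatter)) and (a number 6.3 percentage points lower from compound 1 to compound 4 (within the scatter)), stay within the scatter, so compound 4 cannot be separated from compound 1 or compound 2. Going by these compounds alone, nothing available explains why this rearrangement of atoms is the one step to exceed the scatter.

On these data alone, it remains open whether dimethylamino or a ring amine such as piperidine on this carbonyl carbon would read nearer compound 3 or compound 4. As far as these compounds go, it is also open how a chain longer than butyl on the amide nitrogen would behave.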